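This account rests on a few compounds, and the source may have more. Where it says the series, first, only, none or still open, it means among the compounds named here.

Measured compounds:
compound 1 `C=C(C(=O)OCC)C(OCCC(=O)OCC)c1ccc(Cl)cc1Cl`: 200 nM
compound 2 `C=C(C(=O)OCC)C(O)c1ccccc1F`: 251 nM
compound 3 `C=C(C(=O)OCC)C(O)c1ccccc1[N+](=O)[O-]`: 200 nM

In a functional assay on THP-1 cells (Homo sapiens), read by colorimetric assay, with stated times of 1 h and 1.5 h (on this read-out lower numbers stand for an effect already at smaller amounts and higher numbers for an effect only at larger amounts of compound), compound 1 gives 200 nM. Compound 1 stands level with compound 3 at the digits printed, the two together the lowest of the three numbers; its gap to compound 2 is within the scatter, so the three compounds cannot be told apart on these data. For the measured compounds named here, the only measured step, a 1.3-fold lower number from compound 2 to compound 3 (0.10 log units; within the scatter), exchanges one group for another and says nothing about moving a chlorine around the ring. Compound 4 `C=C(C(=O)OCC)C(OCCC(=O)OCC)c1c(Cl)cccc1Cl` differs from compound 1 in one place: 2,6-dichlorophenyl in place of 2,4-dichlorophenyl on a saturated chain carbon bound to a double-bonded chain carbon and an oxygen on a saturated carbon. Going by the values given here, no measured step bears on this change. The expected step is therefore no change at the digits printed from compound 1 to compound 4 (within the scatter), nothing beyond the scatter. The estimate for compound 4 is 200 nM, within 80 nM to 500 nM.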

Compound 4, half-maximal effective concentration: 126 nM
The estimate for compound 4 lay 1.6-fold (0.20 log units) above the measured number; the range from low to high includes it.
By their numbers in this assay, from the lowest: compounds 4, 1, 3 and 2 (each within the scatter of the next).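

In this assay, 2,6-dichlorophenyl in place of 2,4-dichlorophenyl gives a 1.6-fold lower number from compound 1 to compound 4 (0.20 log units; within the scatter), so this rearrangement of the two chlorines leaves the read-out indistinguishable from that of compound 1. For the compounds shown here, this is the first measured step at this position, and it changes the ring alone while the rest of compound 1 stays the same. Nothing available explains the result.

The compounds shown leave open whether a ring carrying a single chlorine would also stay within the scatter of compound 1. They also leave open how an amine or a carboxylic acid on the ring would read out.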